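Aryl replacement on an aromatic nitrogen: outlook for compound 4

A few compounds are considered here, and "the series" means these few. Any claim that something is new, unique, unknown or untested is made for them only; others in the source may bear on it.

The series shares one core and differs only in the aryl group attached to an aromatic nitrogen. Compound 1 `Cc1cccc(-n2nncc2CN2C(=O)C3(C(C#N)=C(N)Oc4c(N)cc5nc6ccccc6nc5c43)c3ccccc32)c1` carries 3-methylphenyl there. In a functional assay on MCF7 cells (Homo sapiens) for antiproliferative activity, read by MTT assay, with a stated time of 48 h (a lower number here means a stronger inhibitor, a higher number a weaker inhibitor), compound 1 gives > 50000 nM, which is a limit of the assay and not a number. Compound 2 `CCc1cccc(C)c1-n1nncc1CN1C(=O)C2(C(C#N)=C(N)Oc3c(N)cc4nc5ccccc5nc4c32)c2ccccc21` carries 2-ethyl-6-methylphenyl; in this assay compound 2 gives > 50000 nM, again a limit. Compound 3 `CCc1cccc(CC)c1-n1nncc1CN1C(=O)C2(C(C#N)=C(N)Oc3c(N)cc4nc5ccccc5nc4c32)c2ccccc21` carries 2,6-diethylphenyl; in this assay compound 3 gives > 50000 nM, also a limit. The steps a step that the two limits leave unreadable from compound 1 to compound 2, a step that the two limits leave unreadable from compound 1 to compound 3 and a step that the two limits leave unreadable from compound 2 to compound 3 cannot be sized because of the limit of > 50000 nM in this assay, at which 3 of the 3 values shown sit. Compound 3 thus stands at the limit together with the other two, and no ordering among the three can be read.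

Compound 4 `N#CC1=C(N)Oc2c(N)cc3nc4ccccc4nc3c2C12C(=O)N(Cc1cnnn1-c1ccc([N+](=O)[O-])cc1[N+](=O)[O-])c1ccccc12` differs from compound 3 by 2,4-dinitrophenyl in place of 2,6-diethylphenyl on an aromatic nitrogen. Among the measured compounds shown here, all measured steps concern changes within the aryl group on this nitrogen, and none gave a readable size; they show only that three different aryl groups left the series at the limit. The step from compound 3 to compound 4 is therefore expected to be a step that the limit leaves unreadable from compound 3 to compound 4, most likely another result at the limit rather than a measured number. Compound 4 is expected at 60000 nM, with a range from 5000 nM to 200000 nM.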

Compound 4, half-maximal inhibitory concentration: 20900 nM
Estimate against measurement, compound 4: 2.9-fold (0.46 log units) above; the measured number falls inside the stated range.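

Compound 4 is the only compound shown that gives a number in this assay, so the aryl group on this aromatic nitrogen can bring the series inside the readable range, which the three earlier aryl groups did not show. Replacement by 2,4-dinitrophenyl gives an at least 2.3-fold lower number from compound 3 to compound 4 (0.37 log units; beyond the scatter), an at least 2.3-fold lower number from compound 2 to compound 4 (0.37 log units; beyond the scatter) and an at least 2.3-fold lower number from compound 1 to compound 4 (0.37 log units; beyond the scatter), and each of these steps is a bound set by a limit and not a measured size. The change adds 4 hydrogen-bond acceptors where the leaving 2,6-diethylphenyl has none, but that count is only a difference in structure, and the steps among compounds 1, 2 and 3 still cannot be read because of the limit: the limit of > 50000 nM in this assay, at which 3 of the 4 values shown sit.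

Going by these compounds, it stays open whether both nitro groups are needed, or whether a single nitro group, an amine or a carboxylic acid on the same phenyl ring would also give a number in this assay. Among the compounds shown here, with compound 4 as the only readable value, no two numbers can yet be compared at this position, and the true size of the change remains unknown.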